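The source may report more compounds than this note shows. Statements on the series, on what has been measured and on what is new or still open speak of the compounds shown alone.

Measured compounds:
compound 1, `COC(=O)c1cc(-c2cccc(NC(=O)c3ccc(/C=C/C(=O)c4ccc(F)cc4F)cc3)c2)on1`, in an ADME assay on Vero cells (Chlorocebus sabaeus) for cytotoxicity, read by MTT assay, with a stated time of 72 h (a higher number here means that more compound is tolerated, a lower number that less compound is tolerated), compound 1 gives > 40 ug/mL
compound 2, `COC(=O)c1cc(-c2cccc(NC(=O)c3ccc(/C=C/C(=O)c4ccc([N+](=O)[O-])cc4)cc3)c2)on1`, in this assay compound 2 gives > 20 ug/mL

Compound 2 stands at a limit of the assay and not at a number, since its result in this assay is > 20 ug/mL. The result of compound 1 in this assay, > 40 ug/mL, is likewise a limit. Among the measured compounds shown here, the one step between them, a step that the two limits leave unreadable from compound 1 to compound 2, therefore cannot be read, as the two limits the limit of > 20 ug/mL in this assay, at which 1 of the 2 values shown sits, and the limit of > 40 ug/mL in this assay, at which 1 of the 2 values shown sits, show.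

Compound 3, `COC(=O)c1cc(-c2cccc(NC(=O)c3ccc(/C=C/C(=O)c4ccc(Cl)cc4Cl)cc3)c2)on1`, differs from compound 2 by 2,4-dichlorophenyl in place of 4-nitrophenyl on a carbonyl carbon. For the measured compounds named here, the only measured step that bears on a change at this carbonyl carbon is the unreadable one from compound 1 to compound 2, so no size of step in this assay can be expected from it, in either direction, and nothing beyond the scatter is foreseen. Compound 3 is therefore expected to sit near the same limit, with a step that the limit leaves unreadable from compound 2 to compound 3 as the implied step. The estimate for compound 3 in this assay is 40 ug/mL, with a range from 15 ug/mL to 100 ug/mL.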

Compound 3, half-maximal cytotoxic concentration: > 40 ug/mL
Compound 3 ended at the assay's limit; the forecaster's own chance of this, stated with the estimate: 70%; the middle value sits exactly at the limit.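

In this assay compound 3 gives > 40 ug/mL as a limit of the assay and not a number. Among the compounds shown here, the results of compound 1, compound 2 and compound 3 are all limits, so no step among them can be read: the limit of > 40 ug/mL in this assay, at which 2 of the 3 values shown sit. From the compounds shown here alone, how far each compound is tolerated, and whether 4-nitrophenyl, 2,4-difluorophenyl or 2,4-dichlorophenyl on a carbonyl carbon changes this at all, stays open.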